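The compounds below may be only part of what the source reports. "The series", "measured", "known", "first", "only" and "open" are said of these compounds alone.

Compound 1 `CCCN(CC[C@H]1CC[C@H](NC(=O)/C=C/c2ccc(Cl)cc2)CC1)[C@H]1CCc2nc(N)sc2C1`: 2.5 nM
Compound 2 `CCCN(CC[C@H]1CC[C@H](NC(=O)/C=C/c2ccccc2Cl)CC1)[C@H]1CCc2nc(N)sc2C1`: 1.2 nM

In an assay on brain for displacement of a labelled ligand from D(3) dopamine receptor (Rattus norvegicus) (a higher number here means a weaker inhibitor, a lower number a stronger inhibitor), compound 2 gives 1.2 nM, the lowest of the two numbers, while compound 1 gives 2.5 nM. Within the data shown here, the only measured step, a 2.1-fold lower number from compound 1 to compound 2 (0.32 log units; beyond the scatter), bears on the next change. Compound 3 `CCCN(CC[C@H]1CC[C@H](NC(=O)/C=C/c2ccc(OC)cc2)CC1)[C@H]1CCc2nc(N)sc2C1` differs from compound 2 by 4-methoxyphenyl in place of 2-chlorophenyl on a double-bonded chain carbon bound to a double-bonded chain carbon. Among the measured compounds shown here, no measured step involves a methoxy group, so compound 1 with its 4-chlorophenyl is the nearest guide, and its step toward compound 2 ran to a lower number. For compound 3 the expected step is therefore a 2.5-fold higher number from compound 2 to compound 3 (0.40 log units; beyond the scatter), a modest rise. Compound 3 is estimated at 3 nM, within 1 nM to 10 nM.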

Compound 3, inhibition constant: 6.7 nM
The estimate for compound 3 lay 2.2-fold (0.35 log units) below the measured number, and the stated range covers the measured number.
By their numbers in this assay, from the lowest: compound 2; then compound 1; then compound 3.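

In this assay, the exchange of 2-chlorophenyl for 4-methoxyphenyl gives a 5.6-fold higher number from compound 2 to compound 3 (0.75 log units; beyond the scatter) and is the largest step yet at this place. Methoxy in place of chloro on an aromatic carbon gives a 2.7-fold higher number from compound 1 to compound 3 (0.43 log units; beyond the scatter) and so shows that the number responds to the identity of the group as well as to where the chlorine stands. On these data alone, how a nitrile, an amine or a carboxylic acid in place of methoxy on that aromatic carbon would read remains open. Nothing at hand accounts for the rise with methoxy.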